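The compounds below may be only part of what the source reports. "The series", "measured", "known", "first", "only" and "open" are said of these compounds alone.

Going by the values given here, in an ADME assay on cells (Peritoneal macrophage, Mus musculus) for cytotoxicity, read by CCK-8 assay, with a stated time of 24 h (a lower number here means that less compound is tolerated, a higher number that more compound is tolerated), the three compounds measured so far give no numbers, only limits. Compound 1 `COc1ccc(S(=O)(=O)N(CC(N)=O)c2ccc(N(CC(N)=O)S(=O)(=O)c3ccc([S+]([O-])CCCCN=C=S)cc3)c3ccccc23)cc1` gives > 10000 nM, which is a limit. Compound 2 `COc1ccc(S(=O)(=O)N(CC(N)=O)c2ccc(N(CC(N)=O)S(=O)(=O)c3ccc([S+]([O-])CCCCCN=C=S)cc3)c3ccccc23)cc1` gives > 10000 nM, also a limit. Compound 3 `COc1ccc(S(=O)(=O)N(CC(N)=O)c2ccc(N(CC(N)=O)S(=O)(=O)c3ccc(S(=O)(=O)CCN=C=S)cc3)c3ccccc23)cc1` gives > 10000 nM, again a limit, and this is where it stands. Compound 4 `COc1ccc(S(=O)(=O)N(CC(N)=O)c2ccc(N(CC(N)=O)S(=O)(=O)c3ccc(S(=O)(=O)CCOCCOCCOCCN=C=S)cc3)c3ccccc23)cc1` differs from it in one place: a group of 12 heavy atoms (7 carbon, 1 nitrogen, 3 oxygen, 1 sulfur; no ring) in place of a group of 3 heavy atoms (1 carbon, 1 nitrogen, 1 sulfur; no ring), on a saturated chain carbon, two bonds along the chain from a sulfonyl sulfur. The measured steps bearing on this change, a step that the two limits leave unreadable from compound 1 to compound 3 and a step that the two limits leave unreadable from compound 2 to compound 3, have no readable size, and neither has a step that the two limits leave unreadable from compound 1 to compound 2. All that remains is the limit of > 10000 nM in this assay, at which 3 of the 3 values shown sit. No step beyond the scatter, in either direction, is therefore expected in this assay. The expected change, a step that the limit leaves unreadable from compound 3 to compound 4, is only an estimate. Compound 4 is estimated at 15000 nM, within a range of 8000 nM to 50000 nM.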

Compound 4, half-maximal cytotoxic concentration: > 10000 nM
Compound 4 gave a limit, no number; the forecaster's own chance of this, stated with the estimate: 85%; the middle value lies beyond the limit too.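

No step can be read between compound 3 and compound 4 in this assay, as both give only a limit: the limit of > 10000 nM in this assay, at which 4 of the 4 values shown sit.

The compounds shown leave open the half-maximal cytotoxic concentration of each of them, and so whether the chain change in compound 4 matters at all.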